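Replacing the benzoxazole thioether with an enamine-piperazine

The source may report more compounds than this note shows. Statements on the series, on what has been measured and on what is new or still open speak of the compounds shown alone.

Compound 1, `Cn1c(-c2ccc(NC(=O)CSc3nc4ccccc4o3)cc2)nc(-c2ccccc2)c1-c1ccccc1`: 11 ug/mL
Compound 2, `Cn1c(-c2ccc(NC(=O)CSc3nc4cc(Cl)ccc4o3)cc2)nc(-c2ccccc2)c1-c1ccccc1`: 20.6 ug/mL
Compound 3, `Cc1ccc2oc(SCC(=O)Nc3ccc(-c4nc(-c5ccccc5)c(-c5ccccc5)n4C)cc3)nc2c1`: 22.4 ug/mL

In a functional assay on HT-29 cells (Homo sapiens) for cytotoxicity, read by MTT assay, with a stated time of 24 h (a higher number here means a weaker inhibitor, a lower number a stronger inhibitor), compound 3 gives the highest of the three numbers. Its nearest neighbour is compound 2, a 1.1-fold higher number from compound 2 to compound 3 (0.04 log units; within the scatter); its furthest is compound 1, a 2.0-fold higher number from compound 1 to compound 3 (0.31 log units; beyond the scatter). Compound 4, `CN(C)/C=C/N1CCN(CC(=O)Nc2ccc(-c3nc(-c4ccccc4)c(-c4ccccc4)n3C)cc2)CC1`, has not yet been measured. It differs from compound 3 in one place: 4-(2-(dimethylamino)ethenyl)piperazin-1-yl in place of (5-methyl-1,3-benzoxazol-2-yl)sulfanyl on a saturated chain carbon bound to a carbonyl carbon.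

Within the data shown here, none of the measured steps bears directly on this change. The steps of a 1.9-fold higher number from compound 1 to compound 2 (0.27 log units; within the scatter) and a 2.0-fold higher number from compound 1 to compound 3 (0.31 log units; beyond the scatter) concern chloro or methyl in place of hydrogen on the aromatic ring of the group that leaves in compound 4; they say nothing about removing that group and putting a piperazine-based chain in its place. The three measured values span a narrow band, so the expectation for compound 4 is wide and rests on no shown step. Compound 4 is estimated at 30 ug/mL, within 10 ug/mL to 100 ug/mL, a step of a 1.3-fold higher number from compound 3 to compound 4 (0.13 log units; within the scatter) expected from compound 3.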

Compound 4, half-maximal inhibitory concentration: 80 ug/mL
Estimate against measurement, compound 4: 2.7-fold (0.43 log units) below, within the range that was stated.
By their numbers in this assay, from the lowest: compounds 1, 2 and 3 (each within the scatter of the next, the first and the last beyond it); then compound 4.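

In this assay, exchanging the whole group on the saturated chain carbon bound to a carbonyl carbon, rather than decorating its aromatic ring, gives steps that all lie beyond the scatter: a 3.6-fold higher number from compound 3 to compound 4 (0.55 log units; beyond the scatter), a 3.9-fold higher number from compound 2 to compound 4 (0.59 log units; beyond the scatter) and a 7.3-fold higher number from compound 1 to compound 4 (0.86 log units; beyond the scatter). Compound 4 is therefore the weakest inhibitor of the four, so this position is not indifferent to the group it carries, even though the group that enters matches the one that leaves in heavy atoms and hydrogen-bond acceptors as counted. Nothing measured here accounts for the loss.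

The compounds shown leave open whether the piperazine ring or its 2-(dimethylamino)ethenyl arm drives the step. A simple 4-methylpiperazin-1-yl or morpholin-4-yl group on the same carbon would separate the two.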